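This account rests on a few compounds, and the source may have more. Where it says the series, first, only, none or still open, it means among the compounds named here.

Of the compounds shown here, three with a shared core have been measured in a functional assay on RT-112 cells (Homo sapiens) for antiproliferative activity, read by MTT assay, with a stated time of 72 h; a lower number here means a stronger inhibitor of growth, a higher number a weaker inhibitor of growth. Compound 1 (`COc1cc(Nc2ncnc3c(NC(=O)Nc4cc(F)cc(F)c4)cccc23)cc(OC)c1`) gives 2630 nM, compound 2 (`COc1cc(Nc2ncnc3c(NC(=O)Nc4ccc(C(F)(F)F)cc4Cl)cccc23)cc(OC)c1`) gives 1080 nM, and compound 3 (`CCOC(=O)c1ccc(NC(=O)Nc2cccc3c(Nc4cc(OC)cc(OC)c4)ncnc23)cc1`) gives 317 nM, the lowest of the three numbers. Compound 4 (`COc1cc(Nc2ncnc3c(NC(=O)c4cc(=O)c5ccccc5o4)cccc23)cc(OC)c1`) differs from compound 3 at one place, on a carbonyl carbon: a group of 11 heavy atoms (9 carbon, 2 oxygen; one six-membered aromatic ring of carbon only, one six-membered aromatic ring with 1 hetero atom) in place of a group of 12 heavy atoms (9 carbon, 1 nitrogen, 2 oxygen; one six-membered aromatic ring of carbon only), on a carbonyl carbon. The (4-(ethoxycarbonyl)phenyl)amino group leaves, and the group that enters has no common name and carries a six-membered aromatic ring with 1 hetero atom.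

Three measured steps offer a gauge, all of them modest and beyond the scatter: a 2.4-fold lower number from compound 1 to compound 2 (0.39 log units; beyond the scatter), an 8.3-fold lower number from compound 1 to compound 3 (0.92 log units; beyond the scatter) and a 3.4-fold lower number from compound 2 to compound 3 (0.53 log units; beyond the scatter). Within the data shown here, each exchanges only the group on an amide-type nitrogen, and none removes that nitrogen from the carbonyl carbon, so they give a sense of size and no direct precedent. Compound 3 sits at the low end at 317 nM, so a modest move to a higher number is the more likely outcome in this assay, with considerable uncertainty. The expected change is a 2.8-fold higher number from compound 3 to compound 4 (0.45 log units; beyond the scatter). For compound 4 the estimated value is 900 nM, within an expected range of 200 nM to 4000 nM.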

Compound 4, concentration for 50% growth inhibition: > 20000 nM
Compound 4: a limit, no number; the forecaster's own chance of this, stated with the estimate: 10%; middle value at least 22-fold (1.34 log units) from the limit.
By their numbers in this assay, from the lowest: compound 3; then compound 2; then compound 1. At a limit, above all of these: compound 4.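

Compound 4 stands at a limit of the assay, not at a number: the limit of > 20000 nM in this assay, at which 1 of the 4 values shown sits.

Taking the (4-(ethoxycarbonyl)phenyl)amino group off the carbonyl carbon gives an at least 63-fold higher number from compound 3 to compound 4 (1.79 log units; beyond the scatter), and the same comparison with the other two compounds gives an at least 18-fold higher number from compound 2 to compound 4 (1.26 log units; beyond the scatter) and an at least 7.6-fold higher number from compound 1 to compound 4 (0.88 log units; beyond the scatter). Among the compounds shown, this position had so far been varied only in the group on the amide-type nitrogen, which stayed on the carbonyl carbon, and those exchanges moved the number only modestly, whereas the change that removes this nitrogen, with its hydrogen-bond donor, leaves growth inhibition in this assay far weaker than in compound 3 or compound 2.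

The compounds shown do not separate the loss of that nitrogen from the arrival of the six-membered aromatic ring with 1 hetero atom, since the two changes come together in compound 4. An amino group carrying that same ring system on the carbonyl carbon, or a plain phenyl group attached directly there, would tell these apart, and a carboxylic acid in place of the ethyl ester of compound 3 remains an open question as well.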